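A Benzyl Swap on the Shared Nucleoside Core

The source may hold more compounds than are shown below. What is called first, only, known or untested is meant among the compounds shown, and "the series" means these compounds.

Compound 1 `OC[C@H]1O[C@@H](n2cnc3c(NCc4ccc(Cl)c(Cl)c4)ncnc32)[C@H](O)[C@@H]1O` carries a 3,4-dichlorobenzyl group on the shared core. Among the measured compounds shown here, in a functional assay on MCF cells (Homo sapiens) for antiproliferative activity, with a stated time of 72 h (a higher number here means a weaker inhibitor, a lower number a stronger inhibitor), compound 1 gives 88800 nM, the only number among the three values shown. Compound 2 `OC[C@H]1O[C@@H](n2cnc3c(NCc4cc(F)cc(F)c4)ncnc32)C(O)C1O` returns only a limit of the assay, > 166000 nM. Compound 3 `COc1cc(CNc2ncnc3c2ncn3[C@@H]2O[C@H](CO)[C@@H](O)[C@H]2O)cc(OC)c1O` likewise returns a limit, > 166000 nM. The picture is the limit of > 166000 nM in this assay, at which 2 of the 3 values shown sit. Compound 4 `Cc1ccc(O)c(CNc2ncnc3c2ncn3[C@@H]2O[C@H](CO)[C@@H](O)[C@H]2O)c1` has not yet been measured; it differs from compound 1 in one place: 2-hydroxy-5-methylphenyl in place of 3,4-dichlorophenyl on a saturated chain carbon bound to a nitrogen on an aromatic ring. For the measured compounds named here, no step between measured compounds is available, so any expectation rests on compound 1 alone. Compound 4 is expected to show a step of a 1.7-fold higher number from compound 1 to compound 4 (0.23 log units; within the scatter) toward weaker inhibition, possibly beyond the scatter. Compound 4 is therefore estimated at 150000 nM, within 60000 nM to 400000 nM, with a fair chance that only a limit results.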

Compound 4, half-maximal inhibitory concentration: > 166000 nM
Compound 4: only a limit was reported; the forecaster's own chance of this, stated with the estimate: 50%; middle value at least 1.1-fold (0.04 log units) away from the limit.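

Among the compounds shown here, putting 2-hydroxy-5-methylphenyl in place of 3,4-dichlorophenyl gives the first readable step at this position: in this assay the change gives an at least 1.8-fold higher number from compound 1 to compound 4 (0.27 log units; that floor lies within the scatter). As far as these compounds go, compound 4 returns only a limit, so this step is a floor and the true size of the change stays unknown. Compound 1 remains the only compound with a number, while the others share one limit: the limit of > 166000 nM in this assay, at which 3 of the 4 values shown sit.

From the compounds shown here alone, whether a single chlorine or a bromine on the phenyl ring would give a number remains open. So does the outcome with an amine or a carboxylic acid there.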